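This account rests on a few compounds, and the source may have more. Where it says the series, first, only, none or still open, it means among the compounds named here.

Series notes, antagonism at the growth hormone secretagogue receptor.

Two compounds have been run so far in an in vitro functional assay on CHO-CREluc cells for antagonist activity at growth hormone secretagogue receptor type 1 (Homo sapiens), read by a luciferase reporter, with a stated time of 4 h; a lower number here means a stronger inhibitor, a higher number a weaker inhibitor. Compound 1 `Cc1cc2c(cc1Cl)NC(=O)C2(NC(=O)CN1CCN(C)CC1)c1ccc(Cl)cc1Cl` returns only a limit of the assay, > 10000 nM, so no number is available for it. Among the compounds with values here, compound 2 `CCN1CCCC(CC(=O)NC2(c3ccc(Cl)c(Cl)c3)C(=O)Nc3cc(Cl)cc(Cl)c32)C1` gives 47 nM, and this is the only actual number in the set. The other entry, that of compound 1, is the limit (the limit of > 10000 nM in this assay, at which 1 of the 2 values shown sits). Compound 2 therefore cannot be ranked against anything measured. Within the data shown here, no pair of measured compounds differs in a single place, so no measured step exists to lean on.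

Compound 3 `C=CCN1CCN(CC(=O)NC2(c3ccc(Cl)c(Cl)c3)C(=O)Nc3cc(Cl)cc(Cl)c32)CC1` is the next candidate. Relative to compound 2 the change is confined to the saturated chain carbon bound to the carbonyl carbon, where the ring attached there is exchanged: 4-allylpiperazin-1-yl in place of 1-ethylpiperidin-3-yl on a saturated chain carbon bound to a carbonyl carbon. The piperidine of compound 2 is joined through a ring carbon, whereas the piperazine of compound 3 is joined through a ring nitrogen and carries its allyl on the second nitrogen.

Among the measured compounds shown here, with no measured step to calibrate, compound 3 is expected to lose some potency in this assay, the expected step being a 3.2-fold higher number from compound 2 to compound 3 (0.50 log units; beyond the scatter), so the estimate for compound 3 is 150 nM with a range from 40 nM to 800 nM.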

Compound 3, half-maximal inhibitory concentration: 38 nM
Estimate against measurement, compound 3: 3.9-fold (0.60 log units) above; the whole stated range lies above it.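

In this assay, 4-allylpiperazin-1-yl in place of 1-ethylpiperidin-3-yl on a saturated chain carbon bound to a carbonyl carbon comes with a 1.2-fold lower number from compound 2 to compound 3 (0.09 log units; within the scatter), so this position accepts the exchange with no readable difference in potency. The ring is joined through a ring carbon in compound 2 and through a ring nitrogen in compound 3, so for this pair the mode of attachment does not separate the two results, although this single step changes the attachment, the second ring nitrogen and the allyl together and cannot divide them. No measurement shown accounts for this result.

On these data alone, it remains open whether the same reading would hold with a plain ethyl on the piperazine nitrogen, which would separate the allyl from the ring exchange, or with an open-chain dimethylamino group in place of the ring. Compound 1 gives > 10000 nM, a limit of the assay, and it differs from the other compounds in more than one place, so it offers no comparison at this position.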